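A few compounds are considered here, and "the series" means these few. Any claim that something is new, unique, unknown or untested is made for them only; others in the source may bear on it.

Three compounds share one core and differ only in the aryl group attached to the amide nitrogen at the far end of the chain. Compound 1 `CC(=O)c1ccc(NC(=O)/C=C/C(=O)N2C/C(=C\c3ccccc3)C(=O)/C(=C/c3ccccc3)C2)cc1` carries a 4-acetylphenyl group and gives, in a functional assay on Molt4/C8 cells (Homo sapiens) for cytotoxicity (a lower number here means a stronger inhibitor, a higher number a weaker inhibitor), a value of 1400 nM. Compound 2 `Cc1ccc(NC(=O)/C=C/C(=O)N2C/C(=C\c3ccccc3)C(=O)/C(=C/c3ccccc3)C2)cc1`, with a 4-methylphenyl group, gives 660 nM. Compound 3 `Cc1ccc(NC(=O)/C=C/C(=O)N2C/C(=C\c3ccccc3)C(=O)/C(=C/c3ccccc3)C2)cc1C`, with a 3,4-dimethylphenyl group, gives 7900 nM, the highest of the three numbers and therefore the weakest inhibitor among them.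

The step to compound 4 `COc1ccc(NC(=O)/C=C/C(=O)N2C/C(=C\c3ccccc3)C(=O)/C(=C/c3ccccc3)C2)cc1` is 4-methoxyphenyl in place of 3,4-dimethylphenyl on an amide-type nitrogen. Going by the values given here, two measured steps bear on it. Adding a methyl to the ring gave a 12-fold higher number from compound 2 to compound 3 (1.08 log units; beyond the scatter), so removing one again should pull the number back down. Exchanging one single substituent on the ring for another gave a 2.1-fold lower number from compound 1 to compound 2 (0.33 log units; beyond the scatter), a modest change, which suggests that trading methyl for methoxy in the same place would shift the number only a little from where compound 2 or compound 1 sits. Taken together, the step of an 8.8-fold lower number from compound 3 to compound 4 (0.94 log units; beyond the scatter) is expected to be large and downward, because the reverse of a 12-fold higher number from compound 2 to compound 3 (1.08 log units; beyond the scatter) dominates. For compound 4 the estimate is 900 nM, with a plausible range from 400 nM to 2500 nM.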

Compound 4, half-maximal inhibitory concentration: 1100 nM
Compound 4: the middle estimate sits 1.2-fold (0.09 log units) below what was measured; the range from low to high includes it.
By their numbers in this assay, from the lowest: compounds 2, 4 and 1 (each within the scatter of the next, the first and the last beyond it); then compound 3.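

In this assay, the step of a 7.2-fold lower number from compound 3 to compound 4 (0.86 log units; beyond the scatter) places 4-methoxyphenyl on the amide-type nitrogen with the rings that carry a single substituent, away from 3,4-dimethylphenyl. Methoxy also cannot be told apart from the two other single groups: methoxy for methyl gives a 1.7-fold higher number from compound 2 to compound 4 (0.22 log units; within the scatter), and methoxy for acetyl gives a 1.3-fold lower number from compound 1 to compound 4 (0.10 log units; within the scatter), even though methyl and acetyl themselves are separated by a 2.1-fold lower number from compound 1 to compound 2 (0.33 log units; beyond the scatter). Across these four compounds, then, swapping the single group on the ring among acetyl, methyl and methoxy moves the number far less than the second methyl of compound 3 does, and nothing measured here says why that ring stands apart.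

From the compounds shown here alone, what remains open is whether a phenyl ring bearing an amine or a carboxylic acid in place of methoxy would stay close to compounds 1, 2 and 4. Going by these compounds, it is also open whether the large step of a 12-fold higher number from compound 2 to compound 3 (1.08 log units; beyond the scatter) is tied to methyl itself, or whether a 3,4-dimethoxyphenyl group, with its second methoxy, would raise the number in the same way.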